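A few compounds are considered here, and "the series" means these few. Any claim that something is new, unique, unknown or untested is made for them only; others in the source may bear on it.

Measured in an in vitro functional assay on 1321-N1 cells for antagonist activity at transient receptor potential cation channel subfamily V member 1 (Homo sapiens), read by FLIPR and calcium flux; on this read-out lower numbers stand for lower potency and higher numbers for higher potency (the scale is a negative logarithm):

compound 1 `Cc1nc(-c2ccc(F)cc2)ccc1C(=O)Nc1ccc2c(C)n[nH]c2c1`: 6.9
compound 2 `O=C(Nc1ccc2cccnc2c1)c1ccc(-c2ccc(C(F)(F)F)cc2)nc1`: 7.3
compound 3 `Cc1nc(-c2ccc(F)cc2)ccc1C(=O)Nc1ccc2ncn(C)c2c1`: 6.7

Compound 3 stands lowest of the three numbers in this assay. Its nearest neighbour is compound 1, whose value is within the scatter of compound 3, so no order between the two can be read. Compound 2 stands furthest off, with a value beyond the scatter above compound 3; compound 2 also differs from compound 3 in more than one place, so nothing is tied to a single change there.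

The next compound, compound 4 `Cc1nc(-c2ccc(F)cc2)ccc1C(=O)Nc1ccc2nc[nH]c2c1`, is to be measured in this assay. It differs from compound 3 in one place: hydrogen in place of methyl on an aromatic nitrogen.

Among the measured compounds shown here, no step between two measured compounds isolates this change. Compound 1, which carries a hydrogen on a ring nitrogen of its fused system, and compound 3 differ in other places as well, so the value of compound 1, 6.9, and that of compound 3, 6.7, only show that both kinds of fused ring sit close together here. The step from compound 3 to compound 4 is therefore expected to be small, a number 0.10 log units higher from compound 3 to compound 4 (within the scatter), with no direction that can be asserted beyond the scatter. For compound 4 the estimate is 6.8, with a range from 6.3 to 7.3.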

Compound 4, negative logarithm of the antagonist equilibrium constant: 7.2
For compound 4 the middle estimate is 0.40 log units below the measured one, within the range that was stated.
By their numbers in this assay, from the lowest: compounds 3, 1, 4 and 2 (each within the scatter of the next, the first and the last beyond it).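

In this assay, among the compounds shown here, a number 0.50 log units higher from compound 3 to compound 4 (beyond the scatter), and this is the first step that isolates a single change at this position. The aromatic nitrogen of the five-membered ring therefore responds to the loss of one methyl, with hydrogen reading higher than methyl in this pair. That reading rests on one pair only and says nothing of the size of the step on any other core, and no accompanying data bear on why the number moves.

The compounds shown leave open whether any substituent on this nitrogen is compatible with the higher number, or whether an ethyl, a longer chain or a chain ending in an amine would fall further than methyl. Also open, on these data alone, is whether hydrogen in place of methyl gives a step of the same direction in the fused system of compound 1.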